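Series notes: amine swap from compound 2 to compound 4

A few compounds are considered here, and "the series" means these few. Any claim that something is new, unique, unknown or untested is made for them only; others in the source may bear on it.

Numbers so far in a functional assay on A-375 cells (Homo sapiens) for antiproliferative activity, read by CCK-8 assay, with a stated time of 72 h, tested at 2 uM; on this read-out lower numbers stand for a weaker effect and higher numbers for a stronger effect at the one concentration tested:
compound 1 `Nc1ccccc1NC(=O)c1ccc(CSC(=S)N2CCN(c3cccnc3)CC2)cc1` gives 40.5%
compound 2 `Nc1ccccc1NC(=O)c1ccc(CSC(=S)N2CCc3cc(Cl)ccc32)cc1` gives 31.9%
compound 3 `Nc1ccccc1NC(=O)c1ccc(CSC(=S)N2CCN(c3ncccn3)CC2)cc1` gives 24%

Compound 2 holds the second highest of the three numbers. Its nearest neighbour is compound 3, a number lower but within the scatter, and the furthest is compound 1, a number higher and likewise within the scatter, so compound 2 cannot be set apart from either on these readings.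

Compound 4 `CN(Cc1cccnc1)C(=S)SCc1ccc(C(=O)Nc2ccccc2N)cc1` is not yet measured. It differs from compound 2 in one place: methyl((pyridin-3-yl)methyl)amino in place of 5-chloro-2,3-dihydro-1H-indol-1-yl on a thiocarbonyl carbon. For the measured compounds named here, the only step measured so far, a number 16.5 percentage points lower from compound 1 to compound 3 (beyond the scatter), swaps the group on an amine nitrogen in a ring and leaves the group on the thiocarbonyl carbon untouched; it does not bear on the change to compound 4. The pair of compound 2 and compound 3 differs in a different way again, and its gap is within the scatter. The data hold nothing for or against the swap to compound 4. No step beyond the scatter is therefore expected for compound 4: a number 1.1 percentage points higher from compound 2 to compound 4 (within the scatter). The estimate for compound 4 in this assay is 33%, ranging from 18% to 48%.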

Compound 4, a percentage reported as inhibition, at one concentration (the size of the read-out at that concentration, not a potency): 39.4%
Compound 4: the middle estimate sits 6.4 percentage points below what was measured; the measured number falls inside the stated range.
By their numbers in this assay, from the lowest: compounds 3, 2, 4 and 1 (each within the scatter of the next, the first and the last beyond it).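

The first step read at this position, in this assay, is a number 7.5 percentage points higher from compound 2 to compound 4 (within the scatter), so exchanging 5-chloro-2,3-dihydro-1H-indol-1-yl for methyl((pyridin-3-yl)methyl)amino on the thiocarbonyl carbon produces no reading that can be separated from the scatter. For the compounds shown here, the single change removes the chlorine and the five-membered non-aromatic ring and brings in a six-membered aromatic ring with one hetero atom, yet this large change in the group leaves the result in this assay within the usual spread, which is information the earlier step, made on an amine nitrogen in a ring, could not give. No measurement in hand bears on why the two groups read alike.

Going by these compounds, it remains open whether the aromatic ring matters here at all, which a simple dimethylamino group on the thiocarbonyl carbon would test, and whether the ring nitrogen counts, which a benzyl(methyl)amino group in place of methyl((pyridin-3-yl)methyl)amino would test. Also open, on these data alone, is how a longer chain, such as a two-carbon link to the pyridine ring, would read at this position.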